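The compounds below may be only part of what the source reports. "The series", "measured", "known", "first", "only" and "open" are said of these compounds alone.

Measured compounds:
compound 1, `CCC(=O)N1CCc2nc(C#Cc3ccccc3)sc2C1`, 38 nM
compound 2, `O=C(C1CC(F)(F)C1)N1CCc2nc(C#Cc3cccc(F)c3)sc2C1`, > 10000 nM

This account follows a single change on a shared core. Within the data shown here, in an assay on HEK293 cells for negative allosteric modulation of metabotropic glutamate receptor 5 (Homo sapiens), read by FLIPR, with a stated time of 1 h (on this read-out higher numbers stand for weaker inhibition and lower numbers for stronger inhibition), compound 1 gives 38 nM, the only plain number among the values shown. For compound 2 the assay reports only a limit, > 10000 nM, and the limit of > 10000 nM in this assay, at which 1 of the 2 values shown sits, marks where that limit sits. Compound 3, `N#Cc1cccc(C(=O)N2CCc3nc(C#Cc4ccccc4)sc3C2)c1`, has not yet been measured in this assay. It differs from compound 1 in one place: 3-cyanophenyl in place of ethyl on a carbonyl carbon. Among the measured compounds shown here, no pair of measured compounds differing in one place is available, so the size of this step cannot be read from the data; with a change of this kind on the amide carbonyl, a step within the usual scatter, or a modest gain, is expected. Compound 3 is therefore estimated at 30 nM, with a likely range from 8 nM to 150 nM, corresponding to an expected step of a 1.3-fold lower number from compound 1 to compound 3 (0.10 log units; within the scatter).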

Compound 3, half-maximal inhibitory concentration: > 10000 nM
Compound 3: no number, only a limit; the forecaster's own chance of this, stated with the estimate: 5%; middle value at least 330-fold (2.52 log units) away from the limit.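

In this assay, putting 3-cyanophenyl in place of ethyl on the carbonyl carbon gives an at least 260-fold higher number from compound 1 to compound 3 (2.42 log units; beyond the scatter). Among these compounds, this is the first one-place comparison, and it shows that this position does not accept every replacement for ethyl: the small acyl group of compound 1 keeps the inhibition, while this larger aromatic group, with its nitrile, takes it out of the measurable range. The result for compound 3 is a limit and not a number, so the full size of the step stays unknown: the limit of > 10000 nM in this assay, at which 2 of the 3 values shown sit.

The compounds shown leave open whether the loss follows the aromatic ring itself or the nitrile on it, which an unsubstituted phenyl on the same carbonyl carbon would separate. They also leave open how far a longer chain, such as propyl or butyl, could go in place of ethyl.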